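This account rests on a few compounds, and the source may have more. Where it says the series, first, only, none or still open, it means among the compounds named here.

Measured so far in an in vivo functional assay on the whole organism for inhibition of 3-hydroxy-3-methylglutaryl-coenzyme A reductase (Rattus norvegicus), at a dose of 0.2 mg/kg by the oral route; a higher number here means a stronger effect of the compound at the dose given, a lower number a weaker effect:
Compound 1 `Cc1nn(C)c2nc(C3CC3)c(/C=C/[C@@H](O)C[C@@H](O)CC(=O)O)c(-c3ccc(F)cc3)c12` gives 35.5%.
Compound 2 `CC(C)c1nc2c(c(C3CC3)nn2C)c(-c2ccc(F)cc2)c1/C=C/[C@@H](O)C[C@@H](O)CC(=O)O` gives 42.9%.

Of these two numbers compound 2 stands highest, but the gap to compound 1 lies within the usual scatter, so the two cannot be told apart. Compound 3 `Cc1nn(C)c2nc(C(C)C)c(/C=C/[C@@H](O)C[C@@H](O)CC(=O)O)c(-c3ccc(F)cc3)c12` differs from compound 2 by methyl in place of cyclopropyl on an aromatic carbon. For the measured compounds named here, no step between measured compounds of this kind is known, and the two measured values themselves differ only within the scatter. In this assay compound 3 is therefore expected to show no step beyond the scatter, with the estimated change being a number 4.9 percentage points lower from compound 2 to compound 3 (within the scatter). Compound 3 is estimated at 38%, within a range from 20% to 55%.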

Compound 3, a percentage reported as inhibition, in the whole organism at one dose (the size of the read-out at that dose, not a potency): 41.1%
Compound 3: middle estimate off by 3.1 percentage points, on the low side; the range from low to high includes it.
By their numbers in this assay, from the lowest: compounds 1, 3 and 2 (each within the scatter of the next).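

In this assay, for the compounds shown here, methyl in place of cyclopropyl on an aromatic carbon of the five-membered aromatic ring gives a number 1.8 percentage points lower from compound 2 to compound 3 (within the scatter), and the single change that links the other pair gives a number 5.6 percentage points higher from compound 1 to compound 3 (within the scatter). Both single changes stay within the scatter, so at this dose neither exchange separates the compounds, which the earlier pair, differing in two places, could not show. No available measurement bears on this result. As far as these compounds go, whether an amine or phenyl on this aromatic carbon would give a step beyond the scatter remains open.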